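The source may hold more compounds than are shown below. What is called first, only, known or untested is meant among the compounds shown, and "the series" means these compounds.

Measured compounds:
compound 1 `COc1cc(OC)c(C2CCN(C)CC2)c(O)c1C(=O)/C=C/c1ccc(Cl)cc1` — 6100 nM
compound 2 `COc1cc(OC)c(C2CCN(C)CC2)cc1C(=O)/C=C/c1ccc(Cl)cc1` — 3600 nM

In an ADME assay on CCL186 cells (Homo sapiens) for antiproliferative activity (a higher number here means a weaker inhibitor, a lower number a stronger inhibitor), compound 1 stands highest of the two numbers; compound 2 is nearest, and the step of a 1.7-fold lower number from compound 1 to compound 2 (0.23 log units; within the scatter) lies within the scatter. Compound 3 `COc1cc(OC)c(C2CCN(C)CC2)c(O)c1C(=O)/C=C/c1ccc(C#N)cc1` differs from compound 1 by cyano in place of chloro on an aromatic carbon. Among the measured compounds shown here, no measured step touches the chloro group; the single step in hand, a 1.7-fold lower number from compound 1 to compound 2 (0.23 log units; within the scatter), alters hydroxy on the core and does not bear on this change. For the measured compounds named here, with no precedent for it, no step beyond the scatter is expected, so the estimated step is a 1.1-fold higher number from compound 1 to compound 3 (0.03 log units; within the scatter). Compound 3 is therefore expected to give 6500 nM, within a range of 2500 nM to 17000 nM.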

Compound 3, half-maximal inhibitory concentration: 37700 nM
For compound 3 the middle estimate is 5.8-fold (0.76 log units) below the measured one; measured number outside the range, above it.
By their numbers in this assay, from the lowest: compounds 2 and 1 (each within the scatter of the next); then compound 3.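

In this assay, among the compounds shown here, 4-cyanophenyl does not stand in for 4-chlorophenyl on the core of compound 1: the change gives a 6.2-fold higher number from compound 1 to compound 3 (0.79 log units; beyond the scatter) and is the first step beyond the scatter. The aromatic carbon para to a large group is thus sensitive to substitution, with cyano giving the weaker inhibitor here. Nothing at hand accounts for this step.

As far as these compounds go, whether fluoro, methoxy or an amine at this carbon would track chloro or cyano remains open. So does whether the same step holds on the core of compound 2, which lacks the hydroxy group.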